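Swapping a trifluoromethyl for an aminopiperidine arm

The source may report more compounds than this note shows. Statements on the series, on what has been measured and on what is new or still open speak of the compounds shown alone.

Compound 1 `Cc1cn(-c2cc(NC(=O)c3ccc(C)c(Nc4nccc(-c5ccccc5)n4)c3)cc(N3CCNCC3)c2)cn1`: 127 ng.h/mL
Compound 2 `Cc1cn(-c2cc(NC(=O)c3ccc(C)c(Oc4ccccc4)c3)cc(C(F)(F)F)c2)cn1`: 541 ng.h/mL

For the measured compounds named here, in an ADME assay on the whole organism (Mus musculus, strain CD1), read by LC-MS, using cassette dosing, with a stated time of 24 h, at a dose of 0.4 mg/kg by the intravenous route (a lower number here means less compound in the circulation, a higher number more compound in the circulation at the dose given), compound 2 gives 541 ng.h/mL, the higher of the two numbers measured so far; compound 1 gives 127 ng.h/mL, a gap that lies beyond the usual scatter. Going by the values given here, compound 1 differs from compound 2 in more than one place, so no single structural step between the two can be drawn, and their two values simply show where each stands.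

Compound 3 `Cc1cn(-c2cc(CN3CCC[C@H](N)C3)cc(NC(=O)c3ccc(C)c(Oc4ccccc4)c3)c2)cn1` has not yet been measured. It differs from compound 2 in one place: (3-aminopiperidin-1-yl)methyl in place of trifluoromethyl on an aromatic carbon. The rest of the shared core, the amide and the phenoxy-bearing ring are kept unchanged.

Among the compounds with values here, with no measured pair that isolates this change, the expectation rests on the spread of the two numbers available. Compound 3 is expected to fall lower than compound 2 in this assay, by a step of about a 2.7-fold lower number from compound 2 to compound 3 (0.43 log units; beyond the scatter), because compound 1 gives 127 ng.h/mL, and compound 1 is the other compound that carries a nitrogen-containing ring in the same region. The estimate for compound 3 is 200 ng.h/mL, within a range from 70 ng.h/mL to 550 ng.h/mL.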

Compound 3, area under the concentration-time curve: 1470 ng.h/mL
Compound 3: middle estimate off by 7.4-fold (0.87 log units), on the low side; measured number outside the range, above it.
By their numbers in this assay, from the lowest: compound 1; then compound 2; then compound 3.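

At this position, an aromatic carbon meta to a 4-methyl-1H-imidazol-1-yl group, putting (3-aminopiperidin-1-yl)methyl in place of trifluoromethyl gives, in this assay, a 2.7-fold higher number from compound 2 to compound 3 (0.43 log units; beyond the scatter). For the compounds shown here, this is the first change that can be read on its own, and it shows that the position can take a larger group that brings a non-aromatic ring, a hydrogen-bond donor and a defined stereocentre, with more compound in the circulation at the dose given rather than less. The step records only the size and direction of the change, and no measurement shown explains why the number rises.

It remains open which part of the new group accounts for the step: the opposite stereoisomer of the aminopiperidine, or a morpholin-4-ylmethyl group, which has no primary amine, could separate those contributions. This is also a single step on a single scaffold, so it cannot say whether the same swap would raise the number on a different core, such as that of compound 1.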